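Oxadiazole substituent change in a sulfonylpiperidine carboxamide series

A few compounds are considered here, and "the series" means these few. Any claim that something is new, unique, unknown or untested is made for them only; others in the source may bear on it.

Measured compounds:
compound 1, `CCN(CC)S(=O)(=O)c1ccc(S(=O)(=O)N2CCC[C@@H](C(=O)NC3CN(C(=O)C4CC4)C3)C2)cc1`, 3100 nM in a functional assay on MIA PaCa-2 cells (Homo sapiens) for inhibition, read by MTT assay, with a stated time of 3 days; a higher number here means a weaker inhibitor, a lower number a stronger inhibitor
compound 2, `CCN(CC)S(=O)(=O)c1ccc(S(=O)(=O)N2CCC[C@@H](C(=O)N3CCN(c4nc(C)no4)CC3)C2)cc1`, 200 nM
compound 3, `CCN(CC)S(=O)(=O)c1ccc(S(=O)(=O)N2CCC[C@@H](C(=O)NC3COC3)C2)cc1`, 900 nM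

Compound 2 gives the lowest number of the three in this assay; its advantage over compound 3 is a 4.5-fold higher number from compound 2 to compound 3 (0.65 log units; beyond the scatter) in reverse, and over compound 1 it is a 16-fold lower number from compound 1 to compound 2 (1.19 log units; beyond the scatter). Both of those steps replace the whole group on the carbonyl carbon of the shared core. Compound 3 against compound 1 shows a 3.4-fold lower number from compound 1 to compound 3 (0.54 log units; beyond the scatter), again a change of the amide substituent.

Compound 4, `CCN(CC)S(=O)(=O)c1ccc(S(=O)(=O)N2CCC[C@@H](C(=O)N3CCN(c4nc(C(C)C)no4)CC3)C2)cc1`, differs from compound 2 only in that (isopropyl in place of methyl on an aromatic carbon). Within the data shown here, none of the measured steps touches that ring; every step so far alters the group on the carbonyl carbon, so no step here reads directly on this change. Among the measured compounds shown here, with no measured step bearing on the substituent of the 1,2,4-oxadiazol-5-yl, the expected step in this assay is none beyond the scatter, so a 1.1-fold higher number from compound 2 to compound 4 (0.04 log units; within the scatter) is the estimate. Compound 4 is therefore expected to give about 220 nM, within 80 nM to 600 nM.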

Compound 4, half-maximal inhibitory concentration: 30 nM
Beside the measured number, compound 4's estimate is 7.3-fold (0.87 log units) above it; measured number below the stated range.
By their numbers in this assay, from the lowest: compound 4; then compound 2; then compound 3; then compound 1.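

In this assay, among these compounds, the change from 3-methyl-1,2,4-oxadiazol-5-yl to 3-isopropyl-1,2,4-oxadiazol-5-yl gives a 6.7-fold lower number from compound 2 to compound 4 (0.82 log units; beyond the scatter) and is the first reading on this position, as every earlier step replaced the whole group on the carbonyl carbon. The number therefore responds not only to the choice of that whole group but also to the alkyl group on the aromatic carbon between two ring nitrogen atoms, even though neither methyl nor isopropyl carries a hydrogen-bond donor or acceptor. No measurement available here explains this step.

Open, on these data alone, is whether the trend continues with a larger tert-butyl or cyclopropyl group at this position, or whether a straight n-propyl chain matches isopropyl. Also open, as far as these compounds go, is how a hydrogen, an amine or a carboxylic acid on this carbon would read.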